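The source may report more compounds than this note shows. Statements on the series, on what has been measured and on what is new or still open speak of the compounds shown alone.

Measured compounds:
Compound 1 `Cc1cccc(-c2nn(-c3ccc(F)cc3F)cc2CNCCN2CCN(C)CC2)c1` — in an ADME assay on Huh-7 cells (Homo sapiens) for cytotoxicity (a lower number here means that less compound is tolerated, a higher number that more compound is tolerated), compound 1 gives > 20000 nM, which is a limit of the assay rather than a number.
Compound 2 `Cc1ccccc1-c1nn(C(C)C)cc1CNCCN1CCN(C)CC1` — in this assay compound 2 gives > 20000 nM, again a limit of the assay.
Compound 3 `Cc1ccccc1-c1nn(-c2ccc(C(F)(F)F)cc2)cc1CNCCN1CCN(C)CC1` — in this assay compound 3 gives 11000 nM.

Compound 1 therefore stands only at a limit in this assay: all that is known is that it is tolerated up to that point, and the same holds for one other value shown, so that the limit of > 20000 nM in this assay, at which 2 of the 3 values shown sit, applies to most of the small set. The unmeasured compound is compound 4 `COc1ccc(-c2nn(-c3ccc(F)cc3F)cc2CNCCN2CCN(C)CC2)cc1`. It differs from compound 1 in one place: 4-methoxyphenyl in place of 3-methylphenyl on an aromatic carbon. Among the measured compounds shown here, the only measured step, an at least 1.8-fold lower number from compound 2 to compound 3 (0.25 log units; that floor lies within the scatter), concerns a group on an aromatic nitrogen, not the aromatic carbon changed here, and its size is not clearly beyond the scatter; it gives no direct guidance for this change. For the measured compounds named here, with compound 1 at a limit and no step at the relevant place, the expectation for this assay is no change beyond the scatter, a step that the limit leaves unreadable from compound 1 to compound 4. Compound 4 is therefore estimated at 22000 nM, within 9000 nM to 60000 nM, with a fair chance that only a limit is reported again.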

Compound 4, half-maximal cytotoxic concentration: > 20000 nM
Compound 4 gave a limit, no number; the forecaster's own chance of this, stated with the estimate: 60%; the middle value is on the limit's open side.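

In this assay compound 1 and compound 4 both stop at a limit of the assay, not a number, so no step can be read between them. The compounds shown leave open how much of either compound is tolerated past that limit, and so whether 4-methoxyphenyl in place of 3-methylphenyl changes tolerance at all.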